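Amide series: thiophen-2-yl in place of 3-methylphenyl

The source may report more compounds than this note shows. Statements on the series, on what has been measured and on what is new or still open speak of the compounds shown alone.

Measured so far:
compound 1 `Cc1cccc(-c2ccc(CCC(=O)N3CCCC3)cc2)c1`: 16500 nM
compound 2 `O=C(CCCCCCc1cccnc1)N1CCCC1`: > 100000 nM

Going by the values given here, in an assay on HEK293 cells for inhibition of N-acylethanolamine-hydrolyzing acid amidase (Rattus norvegicus), read by LC-MS, with a stated time of 30 min (a lower number here means a stronger inhibitor, a higher number a weaker inhibitor), compound 1 gives 16500 nM, the only actual number in the set. Compound 2 reaches only a limit, (the limit of > 100000 nM in this assay, at which 1 of the 2 values shown sits), and gives no number. Compound 3 `O=C(CCc1ccc(-c2cccs2)cc1)N1CCCC1` differs from compound 1 by thiophen-2-yl in place of 3-methylphenyl on an aromatic carbon. Among the compounds with values here, no measured pair covers a change of this kind, so the expected step for compound 3 is within the scatter, a 1.2-fold higher number from compound 1 to compound 3 (0.08 log units; within the scatter), with no direction claimed. Compound 3 is therefore estimated at 20000 nM, the likely range running from 6000 nM to 70000 nM.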

Compound 3, half-maximal inhibitory concentration: > 100000 nM
Compound 3: a limit, no number (the forecaster's own chance of this, stated with the estimate: 15%); middle value at least 5.0-fold (0.69 log units) from the limit.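

Replacing 3-methylphenyl with thiophen-2-yl on this aromatic carbon gives an at least 6.0-fold higher number from compound 1 to compound 3 (0.78 log units; beyond the scatter) in this assay, so this position does not tolerate every aromatic ring equally. Compound 3 reaches only a limit, so the step gives a minimum and not a size: the limit of > 100000 nM in this assay, at which 2 of the 3 values shown sit.

The compounds shown do not separate the effect of the ring size, the sulfur and the methyl group. From the compounds shown here alone, how plain phenyl, thiophen-3-yl or a 3-aminophenyl group would read at this position also remains open.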